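A few compounds are considered here, and "the series" means these few. Any claim that something is new, unique, unknown or untested is made for them only; others in the source may bear on it.

Measured compounds:
Compound 1, `N[C@H]1CC[C@H](Nc2c(C(=O)NCc3ccccn3)nc(Br)c3cccnc23)CC1`, in a functional assay on MCF7 cells (Homo sapiens) for cytotoxicity, read by MTT assay, with a stated time of 72 h (on this read-out lower numbers stand for stronger inhibition and higher numbers for weaker inhibition), gives 15000 nM.
Compound 2, `C[C@H](CO)Nc1nc(C(=O)NCc2ccc(F)cc2)c(O)c2ncccc12`, in this assay has an entry of "not determined" (no result reported), so no result is reported for it.

For the measured compounds named here, compound 1 is the only compound with a number in this assay, and that number shows weak inhibition; compound 2 supplies no figure to set beside it, so nothing can be said about the gap between compound 1 and compound 2. Compound 3, `CN(C)c1ccc(CNC(=O)c2nc(Br)c3cccnc3c2N[C@H]2CC[C@H](N)CC2)cc1`, has not yet been measured in this assay. It differs from compound 1 in one place: 4-(dimethylamino)phenyl in place of pyridin-2-yl on a saturated chain carbon bound to an amide-type nitrogen. Going by the values given here, no step between measured compounds is available to show what such a change does on this core, so no direction is known from the data. The step from compound 1 to compound 3 is expected to be small, a 1.5-fold lower number from compound 1 to compound 3 (0.18 log units; within the scatter), and within the scatter of the assay. Compound 3 is estimated at 10000 nM in this assay, with a range from 3000 nM to 40000 nM.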

Compound 3, half-maximal inhibitory concentration: 5000 nM
Estimate against measurement, compound 3: 2.0-fold (0.30 log units) above; measured number inside the range.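

In this assay, 4-(dimethylamino)phenyl in place of pyridin-2-yl on a saturated chain carbon bound to an amide-type nitrogen gives a 3.0-fold lower number from compound 1 to compound 3 (0.48 log units; beyond the scatter) on the shared core. This first readable step shows that the number responds to a change at this position, which compound 1 alone could not show, and that this change moves it in the direction of stronger inhibition, though only modestly and on the strength of a single pair. Nothing in the data shown accounts for the step.

The two compounds with numbers do not tell whether the step follows the loss of the pyridine ring nitrogen or the gain of the dimethylamino group, a question that plain phenyl or 4-aminophenyl at this position would bear on. For the compounds shown here, compound 2 carries no number, so no step involving it can be read.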